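Swapping a naphthalene for a methoxyphenyl on the amide branch

The source may hold more compounds than are shown below. What is called first, only, known or untested is meant among the compounds shown, and "the series" means these compounds.

Measured compounds:
- compound 1, `CC1(C)N=C(N)N=C(N)N1c1ccc(CCCCc2ccccc2)cc1`: 8
- compound 2, `CC1(C)N=C(N)N=C(N)N1c1ccc(OCC(=O)Nc2ccc(S(=O)(=O)F)cc2)c(Br)c1`: 8.14
- compound 3, `CC1(C)N=C(N)N=C(N)N1c1ccc(CC(C(=O)Nc2ccc(S(=O)(=O)F)cc2)c2cccc3ccccc23)cc1`: 6.24

All three compounds share the same core and are compared in an assay on isolated protein for inhibition of Dihydrofolate reductase (Mus musculus); on this read-out lower numbers stand for lower potency and higher numbers for higher potency (the scale is a negative logarithm). Compound 1 carries a plain chain ending in a phenyl ring and gives 8. Compound 2, with an amide chain leading to a fluorosulfonylphenyl group, gives 8.14. Compound 3 gives 6.24, the lowest of the three numbers; its distance to compound 1 and to compound 2 lies beyond the usual scatter in each case.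

Compound 4, `COc1cccc(C(Cc2ccc(N3C(N)=NC(N)=NC3(C)C)cc2)C(=O)Nc2ccc(S(=O)(=O)F)cc2)c1`, has not yet been measured. It differs from compound 3 in one place: 3-methoxyphenyl in place of naphthalen-1-yl on a saturated chain carbon bound to a carbonyl carbon and a saturated chain carbon. Among the compounds with values here, no measured pair shows this exact exchange, so the expected direction rests on the neighbouring numbers only. Because compound 1 with a simple phenyl-ended chain reaches 8 while compound 3 sits at 6.24, a moderate rise in this assay is expected, though the amide branch in compound 3 remains in compound 4. The step from compound 3 to compound 4 is estimated at a number 0.66 log units higher from compound 3 to compound 4 (beyond the scatter). Compound 4 is therefore expected to give about 6.9, with a likely range from 6.2 to 7.6.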

Compound 4, logarithm of the reciprocal of the active concentration, log(1/C): 6.46
Beside the measured number, compound 4's estimate is 0.44 log units above it; measured number inside the range.
By their numbers in this assay, from the lowest: compounds 3 and 4 (each within the scatter of the next); then compounds 1 and 2 (each within the scatter of the next).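

In this assay, the exchange of naphthalen-1-yl for 3-methoxyphenyl on the saturated chain carbon bound to a carbonyl carbon and a saturated chain carbon amounts to a number 0.22 log units higher from compound 3 to compound 4 (within the scatter). This position therefore accepts two quite different groups without a difference that can be told from scatter: one has two six-membered aromatic rings and no hydrogen-bond acceptor, while the other has one such ring and one hydrogen-bond acceptor. No measurement shown here addresses why these two groups read alike.

The compounds shown leave open whether this carbon needs an aromatic ring at all, a question that a methyl group, an amine or a carboxylic acid in the same place would address. They also leave open how a plain phenyl compares with these two groups.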